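The source may hold more compounds than are shown below. What is called first, only, known or untested is meant among the compounds shown, and "the series" means these compounds.

Measured so far in an ADME assay on a cell-free system (plasma, Homo sapiens) for protein binding:
compound 1, `Nc1nccc(N2CC[C@H](NC(=O)Nc3ccc(Cl)c(C(F)(F)F)c3)C2)n1`: 99.5%
compound 2, `CNc1nccc(N2CC[C@H](NC(=O)Nc3ccc(C)c(Cl)c3)C2)n1`: 99.3%
compound 3, `CCN1CCN(Cc2ccc(NC(=O)N[C@H]3CCN(c4ccnc(NC)n4)C3)cc2C(F)(F)F)CC1`: 75.2%

In this assay compound 2 gives 99.3%. Among the three values, its unbound fraction is the second highest. Its nearest neighbour is compound 1, whose unbound fraction is lower by an amount that lies within the scatter, so no order can be read between the two. Its furthest neighbour is compound 3, whose unbound fraction is far higher, a gap well beyond the scatter; compound 3 differs from compound 2 in more than one place, so that gap cannot be tied to a single change.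

Compound 4, `CNc1nccc(N2CC[C@H](NC(=O)Nc3cccc(C#N)c3)C2)n1`, has not yet been measured. It differs from compound 2 in one place: 3-cyanophenyl in place of 3-chloro-4-methylphenyl on an amide-type nitrogen. Among the measured compounds shown here, no measured pair shows this exchange, so its size is not known from these data. The change is expected to move the unbound fraction upward by a modest step, a 2.9-fold higher unbound fraction from compound 2 to compound 4 (0.46 log units; beyond the scatter), larger than the scatter but far short of the gap seen for compound 3. Compound 4 is therefore expected to give about 98% in this assay, within a range from 95% to 99.4%.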

Compound 4, plasma protein binding: 94.4%
The estimate for compound 4 lay 2.8-fold (0.45 log units) (unbound fraction) below the measured number; measured number outside the range, below it.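

Among the compounds shown here, this is the first step that can be tied to one place: with the shared core and the methylamino group held fixed, replacing 3-chloro-4-methylphenyl with 3-cyanophenyl on the amide-type nitrogen gives, in this assay, an 8.0-fold higher unbound fraction from compound 2 to compound 4 (0.90 log units; beyond the scatter), a step beyond the scatter. The group on this nitrogen therefore has a measurable bearing on the read-out, even though the two groups have the same heavy-atom count and the same six-membered aromatic ring of carbon, and differ in the hydrogen-bond acceptor count and the triple bond that the 3-cyanophenyl group brings. The data offer no measured basis for explaining why the step has this size.

From the compounds shown here alone, the exchange removes the chlorine and the methyl and adds the nitrile in a single step, so the share of each in the step stays open. Going by these compounds, it is equally open how this position would read with a carboxylic acid or an amine on the phenyl ring, and whether the step would be the same size on the core of compound 1, which has a free amino group in place of the methylamino group.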